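Estimating a Trifluoromethyl Analogue of Compound 1

A few compounds are considered here, and "the series" means these few. Any claim that something is new, unique, unknown or untested is made for them only; others in the source may bear on it.

Measured so far:
Compound 1, `O=C(N/N=C/C1=C(Cl)c2ccccc2CCC1)c1ccccc1`: 1000 nM
Compound 2, `O=C(N/N=C/C1=C(Cl)c2ccccc2CCC1)c1ccc([N+](=O)[O-])cc1`: 2300 nM

In a functional assay (MiaPaCa cells, Homo sapiens) for inhibition, read by sulforhodamine B assay, with a stated time of 48 h (on this read-out lower numbers stand for stronger inhibition of growth and higher numbers for weaker inhibition of growth), compound 1 gives 1000 nM, the lowest of the two numbers; its nearest neighbour is compound 2, which gives 2300 nM, and the step between them, a 2.3-fold higher number from compound 1 to compound 2 (0.36 log units; beyond the scatter), is a modest weakening that lies beyond the scatter. The unmeasured compound 3, `O=C(N/N=C/C1=C(Cl)c2ccccc2CCC1)c1cccc(C(F)(F)F)c1`, differs from compound 1 by trifluoromethyl in place of hydrogen on an aromatic carbon. For the measured compounds named here, the only measured step that bears on this change is the one from compound 1 to compound 2, a different group at a different place on the same ring, so it is a loose guide at best. The analysis therefore expects for compound 3 a small weakening or no change beyond the scatter, and puts its expected step at a 1.5-fold higher number from compound 1 to compound 3 (0.18 log units; within the scatter). Compound 3 is estimated at 1500 nM, within 600 nM to 4000 nM.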

Compound 3, concentration for 50% growth inhibition: 5800 nM
Beside the measured number, compound 3's estimate is 3.9-fold (0.59 log units) below it, and the stated range ends below it.
By their numbers in this assay, from the lowest: compound 1; then compound 2; then compound 3.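

In this assay the trifluoromethyl change is not a neutral one at this carbon, meta to a large group: growth inhibition weakens (a 5.8-fold higher number from compound 1 to compound 3 (0.76 log units; beyond the scatter)), so this place on the ring does not take the group without a loss. Read with the earlier step (a 2.3-fold higher number from compound 1 to compound 2 (0.36 log units; beyond the scatter)), it means that both substituted compounds shown give higher numbers than compound 1, with hydrogen in place of the added group, and neither goes against this. No evidence shown here accounts for the loss in growth inhibition.

Whether the loss follows the trifluoromethyl group itself or this place on the ring stays open, since that group is shown at only one position. From the compounds shown here alone, it also remains open whether a smaller group such as fluorine, or an amine at the same carbon, would match or improve on compound 1.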